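Ester at the Propyl Site of a Pyridyl Ether Ligand

The compounds below may be only part of what the source reports. "The series", "measured", "known", "first", "only" and "open" are said of these compounds alone.

Compound 1 `CN1CCC[C@H]1COc1cccnc1`: 0.15 nM
Compound 2 `Cc1ccncc1OC[C@@H]1CCCN1C`: 4.12 nM
Compound 3 `CCCc1cncc(OC[C@@H]2CCCN2C)c1`: 0.12 nM

In an assay on membranes from brain for displacement of a labelled ligand from Neuronal acetylcholine receptor; alpha4/beta2 (Rattus norvegicus) (on this read-out lower numbers stand for stronger inhibition and higher numbers for weaker inhibition), compound 1 gives 0.15 nM, the second highest of the three numbers; compound 3 sits nearest, with a 1.3-fold lower number from compound 1 to compound 3 (0.10 log units; within the scatter), while compound 2 lies furthest, with a 27-fold higher number from compound 1 to compound 2 (1.44 log units; beyond the scatter). Two steps of a single change from compound 1 have thus been seen, both placing an alkyl group on an aromatic carbon of the shared core, and they diverge: the methyl step was large, the propyl step fell within the scatter.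

Compound 4 `COC(=O)c1cncc(OC[C@@H]2CCCN2C)c1` carries a different kind of group, an ester: methoxycarbonyl in place of hydrogen on an aromatic carbon. Among the measured compounds shown here, its place, two atoms from the ring nitrogen and meta to the group of 8 heavy atoms, is where the alkyl steps give the only guidance here. Compound 3 shows that the core accepts a chain of that size at an aromatic carbon without penalty, because of a 1.3-fold lower number from compound 1 to compound 3 (0.10 log units; within the scatter); compound 2 shows that a substituent on an aromatic carbon can cost a great deal, because of a 27-fold higher number from compound 1 to compound 2 (1.44 log units; beyond the scatter). Weighing the two, a moderate weakening is expected for compound 4, of about a 5.3-fold higher number from compound 1 to compound 4 (0.73 log units; beyond the scatter) in this assay. Compound 4 is therefore estimated at 0.8 nM, with a range from 0.15 nM to 5 nM.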

Compound 4, inhibition constant: 1.45 nM
Estimate against measurement, compound 4: 1.8-fold (0.26 log units) below; the measured number falls inside the stated range.
By their numbers in this assay, from the lowest: compounds 3 and 1 (each within the scatter of the next); then compound 4; then compound 2.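

At this place, two atoms from the ring nitrogen and meta to the group of 8 heavy atoms, the outcome depends on which group enters, not merely on whether the hydrogen is replaced: in this assay methoxycarbonyl gives a 9.7-fold higher number from compound 1 to compound 4 (0.99 log units; beyond the scatter), a step beyond the scatter, whereas the propyl step stayed within it. The direct exchange of the two groups on this aromatic carbon gives a 12-fold higher number from compound 3 to compound 4 (1.08 log units; beyond the scatter), so the acceptance seen for propyl does not extend to methoxycarbonyl, which brings 4 heavy atoms, 2 hydrogen-bond acceptors and a double bond outside aromatic rings. No measurement at hand bears on why these two groups part ways.

The compounds shown do not tell which part of methoxycarbonyl goes with the weaker binding, or whether a carboxylic acid, a primary amide or an acetyl group on this carbon would track the ester or propyl. They also leave open whether a longer chain such as butyl would keep the result seen with propyl, and a single ester cannot establish a trend among esters.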